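Amide substitution on a methylsulfonyl quinolinone scaffold

This account rests on a few compounds, and the source may have more. Where it says the series, first, only, none or still open, it means among the compounds named here.

Three compounds from one series were measured in an assay on CHO-K1 cells for displacement of a labelled ligand from adenosine receptor A1 (Homo sapiens), with a stated time of 2 h; on this read-out lower numbers stand for stronger inhibition and higher numbers for weaker inhibition. Compound 1 `Cn1c(=O)c(S(C)(=O)=O)c(CCc2ccccc2)c2cc(OCC(=O)NCc3ccc(Cl)c(Cl)c3)ccc21` carries a dichlorobenzylamide on an ether-linked acetamide chain; in this assay compound 1 gives only a limit, > 10000 nM. Compound 2 `CS(=O)(=O)c1c(CCc2ccccc2)c2cc(OCC(=O)NCC3CC3)ccc2[nH]c1=O` has a cyclopropylmethyl amide on the same chain; in this assay compound 2 also gives only a limit, > 10000 nM. Compound 3 `CC(C)(NC(=O)NCc1ccc2[nH]c(=O)c(-c3nccs3)c(CCc3ccccc3)c2c1)c1ccccc1`, with a thiazole in place of the methylsulfonyl group and a urea-linked side chain, gives 68 nM in this assay. Compound 2 thus sits at the edge of what the assay can report, as does compound 1: the limit of > 10000 nM in this assay, at which 2 of the 3 values shown sit.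

Compound 4 `CN(Cc1ccc(Cl)c(Cl)c1)C(=O)COc1ccc2[nH]c(=O)c(S(C)(=O)=O)c(CCc3ccccc3)c2c1` differs from compound 2 at a single position: (3,4-dichlorobenzyl)(methyl)amino in place of (cyclopropylmethyl)amino on a carbonyl carbon. This puts (3,4-dichlorobenzyl)(methyl)amino in place of (cyclopropylmethyl)amino on a carbonyl carbon whose other neighbour is a saturated chain carbon. For the measured compounds named here, no measured pair that makes this exact change is available. Since compound 2 already sits at the limit, the step from compound 2 to compound 4 is expected to be a step that the limit leaves unreadable from compound 2 to compound 4, most likely none beyond the scatter. Compound 4 is therefore estimated at 15000 nM in this assay, within 3000 nM to 60000 nM, with a high chance that only a limit is reported.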

Compound 4, inhibition constant: 602 nM
Beside the measured number, compound 4's estimate is 25-fold (1.40 log units) above it; measured number below the stated range.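

The amide position on the carbonyl carbon, which had shown only limits on this chain, proves able to move the number in this assay: (3,4-dichlorobenzyl)(methyl)amino in place of (cyclopropylmethyl)amino gives an at least 16-fold lower number from compound 2 to compound 4 (1.22 log units; beyond the scatter). Among the compounds shown, compound 4 is the only one with the methylsulfonyl group that gives a number rather than a limit, 602 nM. The size of the step is only a lower bound, because compound 2 stands at a limit: the limit of > 10000 nM in this assay, at which 2 of the 4 values shown sit.

The change replaces the whole amine part at once and also removes the amide hydrogen, so the compounds shown do not tell whether the 3,4-dichlorobenzyl group or the methyl on the amide nitrogen carries the step; a (cyclopropylmethyl)(methyl)amino group or a 3,4-dichlorobenzylamino group on the core of compound 4 would separate the two. Compound 1 gives only a limit, > 10000 nM, and differs from compound 4 in two places, so it does not settle the question.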